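The compounds below may be only part of what the source reports. "The series", "measured", "known", "first", "only" and "open" are said of these compounds alone.

Measured so far:
compound 1 `COc1cc(F)ccc1-c1ccnc2[nH]c(C3CCN(CC(=O)N(C)C)CC3)cc12`: 1 h
compound 2 `CC(C)n1cc(-c2ccnc3[nH]c(C4CCN(CC(=O)N(C)C)CC4)cc23)cnc1=O`: 1 h
compound 3 `CC(C)n1cc(-c2ccnc3[nH]c(C4CCN(CC(=O)N(C)C)CC4)cc23)ccc1=O`: 1.7 h

In an ADME assay (Rattus norvegicus, strain Han-wistar) for metabolic stability, at a dose of 1.5 umol/kg by the intravenous route (on this read-out higher numbers stand for a longer-lived compound and lower numbers for a shorter-lived compound), compound 1 stands level with compound 2, and compound 3 lies within the scatter of both. Compound 4 `COc1cc(F)ccc1-c1ccnc2[nH]c(C3CCN(C(C)=O)CC3)cc12` differs from compound 1 by acetyl in place of (dimethylcarbamoyl)methyl on an amine nitrogen in a ring. The measured steps, no change at the digits printed from compound 1 to compound 2 (within the scatter), a 1.7-fold higher number from compound 1 to compound 3 (0.23 log units; within the scatter) and a 1.7-fold higher number from compound 2 to compound 3 (0.23 log units; within the scatter), all stay within the scatter, but each exchanges a group on an aromatic carbon, and none touches this nitrogen. Within the data shown here, the data hold no direct precedent for the change, so the expectation starts from compound 1 at 1 h and carries a wide range. The expected step is a 1.3-fold lower number from compound 1 to compound 4 (0.10 log units; within the scatter), which would be none beyond the scatter in this assay. Compound 4 is estimated at 0.8 h, with an expected range of 0.3 h to 2 h.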

Compound 4, half-life: 0.7 h
Beside the measured number, compound 4's estimate is 1.1-fold (0.06 log units) above it, within the range that was stated.
By their numbers in this assay, from the lowest: compounds 4, 1, 2 and 3 (each within the scatter of the next, the first and the last beyond it).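

In this assay, acetyl in place of (dimethylcarbamoyl)methyl on the amine nitrogen in a ring gives a 1.4-fold lower number from compound 1 to compound 4 (0.15 log units; within the scatter). Among these compounds, this is the first read at this nitrogen, as the earlier steps all exchanged a group on an aromatic carbon, and removing the dimethylamide gives no step beyond the scatter. Nothing measured here accounts for the result.

Open, on these data alone, is how an amine, a carboxylic acid or a longer chain on this nitrogen would read. Also open, as far as these compounds go, is whether acetyl gives a similar step on the aromatic groups of compound 2 and compound 3.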